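The compounds below may be only part of what the source reports. "The series", "measured", "known", "first", "only" and "open" are said of these compounds alone.

In a functional assay on Ehrlich cells (Mus musculus) for cytotoxicity, read by trypan blue exclusion, with a stated time of 2 h, tested at 25 ug/mL (a higher number here means a stronger effect of the compound at the concentration tested, a lower number a weaker effect), compound 2 `N#CC1=C(N)N(c2ccc(S(N)(=O)=O)cc2)C2=C(CCCC2)C1c1cccc([N+](=O)[O-])c1` gives 1%. Compound 1 `N#CC1=C(N)N(c2ccc(S(N)(=O)=O)cc2)C2=C(CCCC2)C1c1ccccc1` gives 10%, and the step of a number 9 percentage points lower from compound 1 to compound 2 (within the scatter) lies within the scatter, so the two numbers cannot be told apart. Compound 3 `Cc1ccc(C2C(C#N)=C(N)N(c3ccc(S(N)(=O)=O)cc3)C3=C2CCCC3)o1` differs from compound 2 by 5-methylfuran-2-yl in place of 3-nitrophenyl on a saturated ring carbon. Going by the values given here, the only measured step also changed the group on that saturated ring carbon and stayed within the scatter, so for compound 3 no step beyond the scatter is expected, the estimated change being a number 7 percentage points higher from compound 2 to compound 3 (within the scatter). Compound 3 is therefore expected to give 8%, between 0% and 30%.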

Compound 3, a percentage reported as activity, at one concentration (the size of the read-out at that concentration, not a potency): 10%
For compound 3 the middle estimate is 2 percentage points below the measured one; the measured number falls inside the stated range.
By their numbers in this assay, from the lowest: compounds 2, 1 and 3 (each within the scatter of the next).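

Replacing a six-membered aromatic ring with a five-membered one on the saturated ring carbon also stays within the scatter in this assay, whether 5-methylfuran-2-yl replaces 3-nitrophenyl (a number 9 percentage points higher from compound 2 to compound 3 (within the scatter)) or phenyl (no change at the digits printed from compound 1 to compound 3 (within the scatter)). Three different groups at this position now cannot be told apart in this read-out, so neither the ring size nor the nitro group shows a measurable effect here. No independent measurement explains this result. On these data alone, whether an amine or a carboxylic acid on this carbon's aromatic ring, or a longer chain in its place, would give a step beyond the scatter remains open.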